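Benzoylguanidine series: replacing the 4-fluorophenyl with isopropoxy

The source may hold more compounds than are shown below. What is called first, only, known or untested is meant among the compounds shown, and "the series" means these compounds.

Measured compounds:
compound 1 `Cc1c(C(=O)N=C(N)N)cc(S(C)(=O)=O)c(Cl)c1Cl`: 29 nM
compound 2 `Cc1cc(-c2ccc(F)cc2)c(S(C)(=O)=O)cc1C(=O)N=C(N)N`: 36 nM
compound 3 `Cc1cc(-c2cc(C(F)(F)F)cc(C(F)(F)F)c2)c(S(C)(=O)=O)cc1C(=O)N=C(N)N`: 2800 nM

In a functional assay for inhibition of sodium/hydrogen exchanger (Oryctolagus cuniculus) (on this read-out lower numbers stand for stronger inhibition and higher numbers for weaker inhibition), compound 2 gives 36 nM and stands second highest of the three numbers. Its nearest neighbour is compound 1, whose number in this assay is 29 nM; the two lie within the scatter of each other, so no order between them can be read. The far end is compound 3 with 2800 nM, a gap well beyond the scatter. Of the two compounds that carry a substituted phenyl on the shared core, only compound 3 loses potency, and with three compounds no pattern can be drawn from this.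

Compound 4 `Cc1cc(OC(C)C)c(S(C)(=O)=O)cc1C(=O)N=C(N)N` is not yet measured. It differs from compound 2 in one place: isopropoxy in place of 4-fluorophenyl on an aromatic carbon

Going by the values given here, no step between two measured compounds bears directly on this change, so the expectation rests on the spread of the three numbers. Compound 2 and compound 1 show that the shared core tolerates unlike groups at this place with the same outcome in this assay; compound 3 shows that a larger group at the same place can cost a lot. Isopropoxy is the smaller of the two groups exchanged, so the step of a 1.1-fold higher number from compound 2 to compound 4 (0.05 log units; within the scatter) is expected to be none beyond the scatter. Compound 4 is estimated at 40 nM in this assay, with a range from 12 nM to 150 nM.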

Compound 4, half-maximal inhibitory concentration: 19 nM
Compound 4: the middle estimate sits 2.1-fold (0.32 log units) above what was measured, and the stated range covers the measured number.
By their numbers in this assay, from the lowest: compounds 4, 1 and 2 (each within the scatter of the next); then compound 3.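

In this assay, going by these compounds alone, the exchange of 4-fluorophenyl for isopropoxy gives the first direct one-place reading at this position: a 1.9-fold lower number from compound 2 to compound 4 (0.28 log units; within the scatter). The position, on an aromatic carbon ortho to a methylsulfonyl group, therefore accepts a group with no ring and one hydrogen-bond acceptor in place of a six-membered aromatic ring with none, without a readable difference, and compound 4 at 19 nM shows that an aromatic ring at this place is not needed for a number of this size. No measurement at hand gives a reason for this tolerance or says how either group acts here.

From the compounds shown here alone, a single pair sets no trend, so it remains open how far the tolerance extends to unlike groups at this position, such as an amine, a carboxylic acid or a longer alkoxy chain like butoxy. Also open, going by these compounds, is whether the ether oxygen of isopropoxy counts for anything, which a plain isopropyl group on the same aromatic carbon would test directly against compound 4.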